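Furan-3-yl for naphthalen-2-yl: a cytotoxicity step

The source may report more compounds than this note shows. Statements on the series, on what has been measured and on what is new or still open speak of the compounds shown alone.

Compound 1 `CC(=O)Nc1cccc(-c2ccc(C(=O)N(Cc3cccc(OCCCCCC(=O)O)c3)C(C)C)cc2)c1` gives > 26000 nM in an ADME assay on HepG2 cells (Homo sapiens) for cytotoxicity, read by CellTiter-Glo and resazurin assay, with a stated time of 72 h (on this read-out higher numbers stand for an effect only at larger amounts of compound and lower numbers for an effect already at smaller amounts), a limit of the assay.
Compound 2 `CC(C)N(Cc1cccc(OCCCCCC(=O)O)c1)C(=O)c1ccc(-c2ccco2)cc1` gives > 26000 nM in this assay, again a limit of the assay.
Compound 3 `CCOC(=O)CCCCCOc1cccc(CN(C(=O)c2ccc(-c3ccc4ccccc4c3)cc2)C(C)C)c1` gives > 26000 nM in this assay, once more a limit of the assay.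

Compound 3 thus stands at the same limit as the other two measured compounds; none of the three has a number, only a limit, as the limit of > 26000 nM in this assay, at which 3 of the 3 values shown sit, shows. Within the data shown here, the only step between measured compounds that differ in one place is a step that the two limits leave unreadable from compound 1 to compound 2, and its size cannot be read because both ends are limits.

Compound 4 `CCOC(=O)CCCCCOc1cccc(CN(C(=O)c2ccc(-c3ccoc3)cc2)C(C)C)c1` is the compound not yet measured. It differs from compound 3 by furan-3-yl in place of naphthalen-2-yl on an aromatic carbon. Among the measured compounds shown here, no measured step speaks directly to this change, and the one step available gives no readable size. The step from compound 3 to compound 4 is therefore expected to be a step that the limit leaves unreadable from compound 3 to compound 4, with the result most likely again a limit rather than a number. For compound 4 the estimate in this assay is 40000 nM, within 20000 nM to 100000 nM.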

Compound 4, half-maximal effective concentration: > 26000 nM
Compound 4 was reported as a limit (the forecaster's own chance of this, stated with the estimate: 85%); the middle value does not contradict the limit.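

No size can be read for the change from compound 3 to compound 4, because both values are limits of the assay: the limit of > 26000 nM in this assay, at which 4 of the 4 values shown sit.

The compounds shown leave open whether any of these group changes alters the result in this assay at all.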